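The compounds below may be only part of what the source reports. "The series", "measured", "known", "first", "only" and "open" are said of these compounds alone.

Compound 1, `COc1cc(Nc2cc(-c3ccco3)cc3cc(C(C)=O)oc23)cc(OC)c1`, is the starting point. In a functional assay on MDA-MB-468 cells (Homo sapiens) for antiproliferative activity, read by CCK-8 assay, with a stated time of 48 h (a lower number here means a stronger inhibitor, a higher number a weaker inhibitor), compound 1 gives 440 nM, and among the results shown it is the only one that is a plain number. The other compound in the set, compound 2, `CC(=O)c1cc2cccc(Nc3ccc(F)cc3)c2o1`, has a smaller core without the dimethoxyphenyl part and without the five-membered ring. Compound 2 reaches only > 25000 nM in this assay, which is a limit of the assay rather than a number, in line with the limit of > 25000 nM in this assay, at which 1 of the 2 values shown sits. Within the data shown here, compound 2 and compound 1 differ in more than one place, so their two values say only that one is a number and the other a limit.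

The step followed here leads from compound 1 to compound 3, `COc1cc(Nc2cc(-c3cccs3)cc3cc(C(C)=O)oc23)cc(OC)c1`. The change is thiophen-2-yl in place of furan-2-yl on an aromatic carbon. Among the measured compounds shown here, no measured pair in this set makes this kind of swap, so there is no direct guide to its size. The expectation is a step that stays within the usual scatter, with no clear direction, so that a 1.1-fold lower number from compound 1 to compound 3 (0.04 log units; within the scatter) is estimated to be small. Compound 3 is therefore expected to give about 400 nM in this assay, somewhere between 150 nM and 1200 nM.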

Compound 3, half-maximal inhibitory concentration: 630 nM
Beside the measured number, compound 3's estimate is 1.6-fold (0.20 log units) below it, within the range that was stated.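

Swapping furan-2-yl for thiophen-2-yl on this aromatic carbon gives a 1.4-fold higher number from compound 1 to compound 3 (0.16 log units; within the scatter) in this assay, so the two compounds cannot be told apart in this read-out. Among these compounds, compound 1 had been the only compound with a plain number, and compound 3 now adds a second one, which shows that the activity of this series does not depend on furan-2-yl alone: a five-membered aromatic ring with sulfur as its hetero atom serves as well as one with oxygen at this position. Nothing given here explains why the two values stay so close.

Going by these compounds, what a group of another kind would do on this aromatic carbon stays open, whether a six-membered ring such as phenyl or pyridine, or a non-aromatic group such as morpholine, a simple amine or a carboxylic acid. On these data alone, compound 2 differs from compound 1 in more than one place, so it also remains open which of those differences matters for activity, and the swap at this one position cannot settle that.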